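A few compounds are considered here, and "the series" means these few. Any claim that something is new, unique, unknown or untested is made for them only; others in the source may bear on it.

In an in vitro assay on cells for inhibition of Amine oxidase [flavin-containing] B (Homo sapiens), read by Amplex Red, with a stated time of 15 min, tested at 100 uM (on this read-out higher numbers stand for more inhibition at the one concentration tested (going by the name of the read-out) and lower numbers for less inhibition), compound 1 `CNC(=S)N1CC(C)C(c2ccc(F)cc2)=N1` gives 40%, and compound 2 `CC1CN(C(N)=S)N=C1c1ccc(F)cc1` gives 40%. For the measured compounds named here, the one measured change, no change at the digits printed from compound 1 to compound 2 (within the scatter), was hydrogen in place of methyl on an amide-type nitrogen, so compound 2 stands level with compound 1 within the scatter. Compound 3 `CC1CN(C(N)=S)N=C1c1ccccc1` differs from compound 2 by hydrogen in place of fluoro on an aromatic carbon. Going by the values given here, no measured step removes a fluoro from the aromatic ring; the only guide is that the single step so far left the read-out unchanged. The expected step is a number 5 percentage points lower from compound 2 to compound 3 (within the scatter), nothing beyond the scatter or a slight loss. Compound 3 is therefore estimated at 35%, within 15% to 55%.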

Compound 3, a percentage reported as inhibition, at one concentration (the size of the read-out at that concentration, not a potency): 40%
Beside the measured number, compound 3's estimate is 5 percentage points below it, and the stated range covers the measured number.
By their numbers in this assay, from the lowest: compounds 1, 2 and 3 (each within the scatter of the next).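

Putting hydrogen in place of fluoro on the aromatic carbon gives no change at the digits printed from compound 2 to compound 3 (within the scatter) in this assay, so this read-out at its one tested concentration shows no difference at this ring position, as it showed none at the amide-type nitrogen. The fluoro is thus not needed to hold this level of inhibition in these compounds. Nothing measured here offers an explanation for this result.

From the compounds shown here alone, whether a larger group at this position, such as methoxy or an amine, would move the read-out stays open. A single concentration also leaves the potency of these compounds unknown.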